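Chain length and cytotoxicity in a cyclic phosphate nucleoside series

The source may report more compounds than this note shows. Statements on the series, on what has been measured and on what is new or still open speak of the compounds shown alone.

Compound 1 `CCCCCc1cn([C@@H]2O[C@@H]3CO[PH](O)(O)O[C@H]3[C@H]2O)c(=O)nc1N`, compound 2 `CCCc1cn([C@@H]2O[C@@H]3CO[PH](O)(O)O[C@H]3[C@H]2O)c(=O)nc1N` and compound 3 `CCc1cn([C@@H]2O[C@@H]3COP(=O)(O)O[C@H]3[C@H]2O)c(=O)nc1N` share a core and differ in a saturated chain. In a functional assay on L1210 cells (Mus musculus) for cytotoxicity (on this read-out lower numbers stand for stronger inhibition and higher numbers for weaker inhibition), compound 1 gives only a limit, > 200 ug/mL. In this assay compound 2 also gives only a limit, > 200 ug/mL. Compound 3 too gives only a limit in this assay, > 200 ug/mL. The step that the two limits leave unreadable from compound 2 to compound 1 is the change (ethyl in place of hydrogen on a saturated chain carbon, three bonds along the chain from an aromatic carbon); with both ends at the limit of > 200 ug/mL in this assay, at which 3 of the 3 values shown sit, its size cannot be read. The difference between the cores of compound 2 and compound 3 is not broken down here.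

Compound 4 `CCCCc1cn([C@@H]2O[C@@H]3COP(=O)(O)O[C@H]3[C@H]2O)c(=O)nc1N` is yet to be measured in this assay. It differs from compound 3 by ethyl in place of hydrogen on a saturated chain carbon, two bonds along the chain from an aromatic carbon, the same kind of change as from compound 2 to compound 1, but sitting two bonds along the chain from an aromatic carbon rather than three bonds along the chain from an aromatic carbon. The step that the limit leaves unreadable from compound 3 to compound 4 is expected to be near zero, since the measured step that the two limits leave unreadable from compound 2 to compound 1 shows no readable movement and every value stands at the limit of > 200 ug/mL in this assay, at which 3 of the 3 values shown sit. Compound 4 is expected to give about 300 ug/mL, most probably again only a limit, within 120 ug/mL to 1000 ug/mL.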

Compound 4, concentration for 50% inhibition: > 200 ug/mL
Compound 4: a limit, no number; the forecaster's own chance of this, stated with the estimate: 90%; the middle value is on the limit's open side.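

Compound 4 gives only a limit, as do compound 1, compound 2 and compound 3, so no new step can be read from compound 3 to compound 4 or elsewhere in the set. The compounds shown leave open whether any chain on these cores gives a number in this assay rather than a limit, and how large a chain step would then be.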